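Ring methyl and cytotoxicity limits in the benzyl series

This account rests on a few compounds, and the source may have more. Where it says the series, first, only, none or still open, it means among the compounds named here.

Measured so far:
Compound 1 `O=c1cc(Cc2c(F)cccc2F)nc(SCc2ccccc2)[nH]1`: in an ADME assay on MT4 cells (Homo sapiens) for cytotoxicity, read by MTT assay (on this read-out lower numbers stand for higher toxicity in this test and higher numbers for lower toxicity in this test), compound 1 gives > 73000 nM, a limit of the test, not a number.
Compound 2 `Cc1c(Cc2c(F)cccc2F)nc(SCc2ccccc2)[nH]c1=O`: in this assay compound 2 gives > 70000 nM, also a limit.
Compound 3 `O=C(CSc1nc(Cc2c(Cl)cccc2Cl)cc(=O)[nH]1)c1ccccc1`: in this assay compound 3 gives > 12000 nM, again a limit.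

The change from compound 1 to compound 2 is methyl in place of hydrogen on an aromatic carbon. In this assay it gives a step that the two limits leave unreadable from compound 1 to compound 2, unreadable because the limit of > 73000 nM in this assay, at which 1 of the 3 values shown sits, and the limit of > 70000 nM in this assay, at which 1 of the 3 values shown sits, both mark only the limits of the test. Compound 4 `Cc1c(Cc2c(Cl)cccc2Cl)nc(SCC(=O)c2ccccc2)[nH]c1=O`, not yet measured, is related to compound 3 by methyl in place of hydrogen on an aromatic carbon, the same kind of change, though the surroundings differ: in compound 1 the carbon is ortho to a group of 9 heavy atoms and para to a benzylsulfanyl group (8 heavy atoms), whereas in compound 3 it is ortho to a 2,6-dichlorobenzyl group (9 heavy atoms) and para to a large group. The difference between the two cores is not broken down here. Compound 3 stands only at a limit, (the limit of > 12000 nM in this assay, at which 1 of the 3 values shown sits). For compound 4 the step that the limit leaves unreadable from compound 3 to compound 4 in this assay is expected to be small, resting on compound 2 having stayed at a limit after the same kind of change. Compound 4 is therefore expected near 40000 nM, most likely again reported only as a limit.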

Compound 4, half-maximal cytotoxic concentration: > 60000 nM
Compound 4: a limit, no number (the forecaster's own chance of this, stated with the estimate: 75%); middle value at least 1.5-fold (0.17 log units) from the limit.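

In this assay compound 4 gives > 60000 nM, a limit and not a number, and compound 3 also stands only at a limit, so no step can be read between these two compounds. The compounds shown leave open whether methyl in place of hydrogen on the aromatic carbon changes the half-maximal cytotoxic concentration at all.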